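Para-Fluoro on the Anilino Group: Compound 2 to Compound 3

A few compounds are considered here, and "the series" means these few. Any claim that something is new, unique, unknown or untested is made for them only; others in the source may bear on it.

Compound 1, `CN1CCN(c2ccc(Nc3ncc4nc(Nc5ccc(F)cc5)n([C@H]5CCCNC5)c4n3)cc2)CC1`: "not determined" (no result reported)
Compound 2, `CN1CCN(c2ccc(Nc3ncc4nc(Nc5ccccc5)n([C@H]5CCN(S(=O)(=O)C6CC6)C5)c4n3)cc2)CC1`: 240 nM

Two compounds share a core and a methylpiperazinyl-phenylamino arm. For compound 1 the outcome in a functional assay on NCI-H1975 cells (Homo sapiens) for antiproliferative activity, read by MTT assay, with a stated time of 72 h (on this read-out lower numbers stand for stronger inhibition and higher numbers for weaker inhibition), is "not determined" (no result reported), so no number stands against it. Among the compounds with values here, compound 2 is therefore the only compound with a figure: in this assay compound 2 gives 240 nM, and it stands alone, with nothing to compare it against.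

Compound 3, `CN1CCN(c2ccc(Nc3ncc4nc(Nc5ccc(F)cc5)n([C@H]5CCN(S(=O)(=O)C6CC6)C5)c4n3)cc2)CC1`, is the next compound. It differs from compound 2 in one place: fluoro in place of hydrogen on an aromatic carbon. Within the data shown here, the difference is small, and no measured pair of this kind is available here to show what such a change does on this core. A step no larger than the usual scatter of this assay is expected, in either direction, so the estimated step of a 1.2-fold lower number from compound 2 to compound 3 (0.08 log units; within the scatter) is near zero. Compound 3 is thus expected to give about 200 nM, with a likely range from 80 nM to 500 nM.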

Compound 3, half-maximal inhibitory concentration: 580 nM
The estimate for compound 3 lay 2.9-fold (0.46 log units) below the measured number; measured number above the stated range.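

In this assay, within the data shown here, the change from anilino to (4-fluorophenyl)amino gives a 2.4-fold higher number from compound 2 to compound 3 (0.38 log units; beyond the scatter), the first measured step on the shared core. A single fluoro on this aromatic carbon, para to a large group, thus moves the number beyond the scatter and towards weaker inhibition, so this position is not indifferent to even a one-atom change. No measurement at hand accounts for the size or direction of this step.

On these data alone, whether chloro, methoxy or an amine at the same place would raise the number further or bring it back towards that of compound 2 remains open. So does whether fluoro gives a step of this size when the cyclopropylsulfonyl group is replaced by an acetyl group.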